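This account rests on a few compounds, and the source may have more. Where it says the series, first, only, none or still open, it means among the compounds named here.

Compound 2 `O=C(Cc1csc2nc(-c3ccc(Br)cc3)cn12)N/N=C/c1ccccc1O` carries a 2-hydroxyphenyl group on the carbon with a double bond to nitrogen, and in a functional assay on SF-268 cells (Homo sapiens) for inhibition, read by sulforhodamine B assay, with a stated time of 48 h (a lower number here means a stronger inhibitor of growth, a higher number a weaker inhibitor of growth), compound 2 gives only a limit, < 100000 nM. Its parent, compound 1 `O=C(Cc1csc2nc(-c3ccc(Br)cc3)cn12)N/N=C/c1ccccc1`, differs only by hydroxy in place of hydrogen on an aromatic carbon, and in this assay compound 1 likewise gives only a limit, < 100000 nM. The step that the two limits leave unreadable from compound 1 to compound 2 therefore cannot be read, since the limit of < 100000 nM in this assay, at which 2 of the 2 values shown sit, holds both values.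

Compound 3 `O=C(Cc1csc2nc(-c3ccc(Br)cc3)cn12)N/N=C/c1ccc(Cl)cc1Cl` is the next member and has not yet been measured. It differs from compound 2 as follows: 2,4-dichlorophenyl in place of 2-hydroxyphenyl on a carbon with a double bond to nitrogen. No measured step bears on this change, because the single step shown, from compound 1 to compound 2, is unreadable and concerns a different position. With nothing to guide direction or size, compound 3 is expected to sit near the same region, with an expected step that the limit leaves unreadable from compound 2 to compound 3. The estimate for compound 3 in this assay is 30000 nM, within a range from 5000 nM to 100000 nM.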

Compound 3, concentration for 50% growth inhibition: < 100000 nM
Compound 3 was reported as a limit; the forecaster's own chance of this, stated with the estimate: 50%; the middle value lies beyond the limit too.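

Compound 3 adds no readable step against compound 1 or compound 2, because all three compounds rest on the same limit: the limit of < 100000 nM in this assay, at which 3 of the 3 values shown sit.

The compounds shown leave open how far compound 1, compound 2 and compound 3 actually lie apart in this assay, and whether the 2,4-dichlorophenyl group changes growth inhibition at all.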